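Half-life of a phenoxy analogue, estimated from two ethers

The source may hold more compounds than are shown below. What is called first, only, known or untested is meant among the compounds shown, and "the series" means these compounds.

Compound 1 `C=CC(=O)NCc1coc(-c2c(N)ncnc2Nc2ccc(OCc3ccccn3)c(F)c2)n1`: 0.45 h
Compound 2 `C=CC(=O)NCc1coc(-c2c(N)ncnc2Nc2ccc(OCc3cccc(F)c3)c(Cl)c2)n1`: 0.75 h

In an in vitro ADME assay on microsomes from liver (Homo sapiens) for metabolic stability, tested at 5 uM (on this read-out higher numbers stand for a longer-lived compound and lower numbers for a shorter-lived compound), compound 1 gives 0.45 h and compound 2 gives 0.75 h. The gap between these two values is within the usual scatter of the measurement, so neither compound is set apart from the other. Compound 3 `C=CC(=O)NCc1coc(-c2c(N)ncnc2Nc2ccc(Oc3ccccc3)c(Cl)c2)n1` differs from compound 2 in one place: phenyl in place of 3-fluorobenzyl on an oxygen on an aromatic ring. For the measured compounds named here, no measured pair covers this change, so the step from compound 2 to compound 3 is expected to be small, likely within the scatter, in this assay: a 1.1-fold higher number from compound 2 to compound 3 (0.03 log units; within the scatter). Compound 3 is therefore estimated at 0.8 h, expected to fall between 0.4 h and 1.6 h.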

Compound 3, half-life: > 1.66 h
Compound 3: only a limit was reported; the forecaster's own chance of this, stated with the estimate: 5%; at least 2.0-fold (0.31 log units) between middle value and limit.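

In this assay, phenyl in place of 3-fluorobenzyl on this oxygen gives the first gap beyond the scatter among these compounds: an at least 2.2-fold higher number from compound 2 to compound 3 (0.34 log units; beyond the scatter). Compound 3 has only a limit, > 1.66 h, and not an exact number. The full size of the step therefore stays unknown, and what is known of it rests on this: the limit of > 1.66 h in this assay, at which 1 of the 3 values shown sits.

On these data alone, it remains open whether plain benzyl or 3-fluorophenyl on the same oxygen would stand closer to compound 2 or to compound 3. The shown compounds therefore cannot separate the role of the fluorine from that of the carbon linking the ring to the oxygen.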